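A few compounds are considered here, and "the series" means these few. Any claim that something is new, unique, unknown or untested is made for them only; others in the source may bear on it.

Measured so far in an assay on NIH3T3 cells for displacement of a labelled ligand from melatonin receptor type 1B (Homo sapiens), with a stated time of 90 min; on this read-out lower numbers stand for stronger inhibition and higher numbers for weaker inhibition:
- compound 1, `CC(=O)NCC(C)Oc1ccccc1`: 1150 nM
- compound 2, `CC(=O)NCCOc1ccccc1`: 5500 nM
- compound 3, `COc1cccc(SCCNC(C)=O)c1`: 39.8 nM

Compound 3 gives the lowest of the three numbers; compound 1 and compound 2 both sit well above it, beyond the scatter. Compound 4, `CC(=O)NCCSc1ccccc1`, differs from compound 3 by hydrogen in place of methoxy on an aromatic carbon.

Within the data shown here, the only measured step, a 4.8-fold higher number from compound 1 to compound 2 (0.68 log units; beyond the scatter), concerns a methyl on the chain and not the aromatic methoxy, so no measured step covers the change at hand. Among the measured compounds shown here, what can be said is that the one compound carrying the methoxy, compound 3, also carries the lowest number, while the two compounds lacking it, compound 1 and compound 2, lie far higher; the sulfur linker of compound 3 is a second difference and is not separated by any step.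

Compound 4 is therefore expected to show a higher number than compound 3, an estimated step of a 15-fold higher number from compound 3 to compound 4 (1.18 log units; beyond the scatter), with wide uncertainty. The estimate for compound 4 in this assay is 600 nM, within a range from 100 nM to 4000 nM.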

Compound 4, inhibition constant: 339 nM
Estimate against measurement, compound 4: 1.8-fold (0.25 log units) above; low and high end bracket the measured number.
By their numbers in this assay, from the lowest: compound 3; then compound 4; then compound 1; then compound 2.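

Working from this assay, the methoxy can now be read apart from the sulfur linker: on an aromatic carbon, meta to a group of 7 heavy atoms, its replacement by hydrogen gives an 8.5-fold higher number from compound 3 to compound 4 (0.93 log units; beyond the scatter). Compound 4 also pairs with compound 2 at the linker atom alone, with sulfur in compound 4 at 339 nM and oxygen in compound 2 at 5500 nM, so the sulfur compound keeps the lower number even without the methoxy. Nothing available explains either difference.

Open, going by these compounds, is whether a hydroxyl, an ethoxy or a chlorine on this carbon would match the methoxy, and whether the methoxy would count the same on another ring carbon. Also open, on these data alone, is whether the chain methyl behind a 4.8-fold higher number from compound 1 to compound 2 (0.68 log units; beyond the scatter) carries over to the sulfur-linked compounds.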